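Trimming a Methyl from the Sulfur Substituent

This account rests on a few compounds, and the source may have more. Where it says the series, first, only, none or still open, it means among the compounds named here.

Compound 1 `Cn1ncc2c(=O)n(-c3ccccc3)c(SC(C)(C)c3ccccc3)nc21`: 1390 nM
Compound 2 `Cn1ncc2c(=O)n(-c3ccccc3)c(SCc3cccc(F)c3)cc21`: 140 nM
Compound 3 `CC(Sc1nc2c(cnn2C)c(=O)n1-c1ccc(CCO)cc1)c1ccccc1`: 3000 nM

These three compounds were tested in an assay on isolated protein for inhibition of Retinaldehyde dehydrogenase 3 (Homo sapiens); a lower number here means a stronger inhibitor, a higher number a weaker inhibitor. Among them compound 1 gives the second highest number, 1390 nM. Its nearest neighbour is compound 3, which gives 3000 nM, a gap that is beyond the scatter, while the furthest away is compound 2, which gives 140 nM, a much lower number.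

Compound 4 `C[C@H](Sc1nc2c(cnn2C)c(=O)n1-c1ccccc1)c1ccccc1` has not yet been measured. It differs from compound 1 in one place: 1-phenylethyl in place of 1-methyl-1-phenylethyl on a sulfur. Among the measured compounds shown here, no pair of measured compounds shows this exact change, so no step can be borrowed directly. The change removes one carbon and introduces one defined stereocentre but leaves donors, acceptors and charge unchanged, so only a modest step is expected, in either direction or none beyond the scatter. Compound 4 is therefore expected to land at about 1200 nM, within 400 nM to 3500 nM, which corresponds to an expected step of a 1.2-fold lower number from compound 1 to compound 4 (0.06 log units; within the scatter).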

Compound 4, half-maximal inhibitory concentration: 1640 nM
Compound 4: middle estimate off by 1.4-fold (0.14 log units), on the low side; the measured number falls inside the stated range.
By their numbers in this assay, from the lowest: compound 2; then compounds 1, 4 and 3 (each within the scatter of the next, the first and the last beyond it).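

In this assay replacing 1-methyl-1-phenylethyl with 1-phenylethyl on the sulfur gives a 1.2-fold higher number from compound 1 to compound 4 (0.07 log units; within the scatter) and so makes no measurable difference. Among the compounds shown here, this is the first direct reading at this position: removing one carbon and adding a defined stereocentre leaves the number unchanged within the scatter. No supporting measurement bears on why the change has so little effect.

Still open, on these data alone, is whether the opposite stereoisomer of compound 4 would read the same. Also unknown is how a plain benzyl group, or a longer chain ending in an amine, would behave on this sulfur.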